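Lengthening a Side Chain: From Compound 3 to Compound 4

A few compounds are considered here, and "the series" means these few. Any claim that something is new, unique, unknown or untested is made for them only; others in the source may bear on it.

In a functional assay on MCF7 cells (Homo sapiens) for cytotoxicity, read by MTT assay, with a stated time of 72 h (a lower number here means a stronger inhibitor of growth, a higher number a weaker inhibitor of growth), three compounds have been measured:
- compound 1 `CCCOC(=O)Nc1ccc([Se]C#N)cc1` gives 8000 nM
- compound 2 `CC(C)COC(=O)Nc1ccc([Se]C#N)cc1` gives 18100 nM
- compound 3 `C=CCOC(=O)Nc1ccc([Se]C#N)cc1` gives 15000 nM

Compound 3 holds the second highest of the three numbers. Its nearest neighbour is compound 2, separated by a 1.2-fold lower number from compound 2 to compound 3 (0.08 log units; within the scatter), and its furthest is compound 1, separated by a 1.9-fold higher number from compound 1 to compound 3 (0.27 log units; within the scatter); both of these gaps lie within the scatter, so the three numbers cannot be ordered with confidence. Among the compounds with values here, the only step beyond the scatter is a 2.3-fold higher number from compound 1 to compound 2 (0.35 log units; beyond the scatter), a modest one.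

Compound 4 `CCCCCCOC(=O)Nc1ccc([Se]C#N)cc1` differs from compound 3 by pentyl in place of vinyl on a saturated chain carbon bound to an oxygen next to a carbonyl group. Within the data shown here, none of the measured steps changes the chain in this way: the steps into compound 3 swap the group on the same carbon for one of similar size, and the step from compound 1 to compound 2 adds a branch. Those steps were small or within the scatter, so the expectation for compound 4 in this assay is a change of no more than modest size, in either direction. The estimated step is a 1.4-fold lower number from compound 3 to compound 4 (0.13 log units; within the scatter), and compound 4 is expected to give 11000 nM, within a range of 3500 nM to 35000 nM.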

Compound 4, concentration for 50% growth inhibition: 6600 nM
Estimate against measurement, compound 4: 1.7-fold (0.22 log units) above; low and high end bracket the measured number.
By their numbers in this assay, from the lowest: compounds 4, 1, 3 and 2 (each within the scatter of the next, the first and the last beyond it).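

In this assay, within the data shown here, exchanging the group on a saturated chain carbon bound to an oxygen next to a carbonyl group now produces steps beyond the scatter, a 2.3-fold lower number from compound 3 to compound 4 (0.36 log units; beyond the scatter) for pentyl in place of vinyl and a 2.7-fold lower number from compound 2 to compound 4 (0.44 log units; beyond the scatter) for pentyl in place of isopropyl, whereas the earlier steps at this place, the vinyl exchanges, stayed within it. Chain length alone is not resolved, however: a 1.2-fold lower number from compound 1 to compound 4 (0.08 log units; within the scatter) lies within the scatter, so extending the unbranched chain of compound 1 to the hexyl of compound 4 produces no readable change, and the separation seen here holds for compound 4 against compound 2 and compound 3 but not against compound 1. The data at hand give no measured basis for explaining any of these steps.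

Still open, from the compounds shown here alone, is whether a chain longer than hexyl would give a number that differs from those of compound 1 and compound 4 by more than the scatter. The compounds shown also leave open how a cyclohexyl or phenyl ring, or an ether oxygen or an amine within the chain, would behave at this place.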